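The compounds below may be only part of what the source reports. "The series", "measured", "known", "first", "only" and "open" are said of these compounds alone.

Working notes on the series in a physicochemical assay for solubility, read by spectrophotometry, in phosphate buffer, with a stated time of 18 h, at pH 7.4; a lower number here means a less soluble compound, a higher number a more soluble compound. Compound 1 `CCc1ccc(-c2nc3c(c(C)nn3-c3ccccc3)c(-c3ccccc3OC)c2C#N)cc1` gives 7800 nM and compound 2 `CCc1ccc(-c2nc3c(c(C)nn3-c3ccccc3)c(-c3ccc(O)cc3)c2C#N)cc1` gives 5700 nM in this read-out. Compound 3 `Cc1ccccc1-c1nc2c(c(C)nn2-c2ccccc2)c(-c2ccccc2O)c1C#N` stands highest of the three at 21000 nM and lies beyond the scatter of both others.

The next structure is compound 4 `Cc1nn(-c2ccccc2)c2nc(-c3ccc(C#N)cc3)c(C#N)c(-c3ccccc3O)c12`, and the difference is 4-cyanophenyl in place of 2-methylphenyl on an aromatic carbon in the shared core. In words, this is 4-cyanophenyl in place of 2-methylphenyl on an aromatic carbon, next to the ring nitrogen and ortho to a cyano group.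

Within the data shown here, the only measured single-place step is a 1.4-fold lower number from compound 1 to compound 2 (0.14 log units; within the scatter) and it sits at a different place, so it shows only that one swap there stayed small. Among the measured compounds shown here, no measured step changes the group at this place. Compound 1 and compound 2 carry another aryl group there, but each also differs from compound 3 elsewhere, so their gaps to compound 3 are not clean steps. Still, compound 1 at 7800 nM and compound 2 at 5700 nM suggest that compound 3 may not be the typical level, and a moderate fall in this assay is expected.

The expected step is a 2.3-fold lower number from compound 3 to compound 4 (0.37 log units; beyond the scatter) on thin evidence. For compound 4 the estimate is 9000 nM with an expected range of 3000 nM to 21000 nM in this read-out.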

Compound 4, solubility: 1700 nM
Compound 4: middle estimate off by 5.3-fold (0.72 log units), on the high side, outside the stated range (below it).
By their numbers in this assay, from the lowest: compound 4; then compounds 2 and 1 (each within the scatter of the next); then compound 3.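

In this assay, among these compounds, replacing 2-methylphenyl with 4-cyanophenyl on the aromatic carbon next to the ring nitrogen and ortho to a cyano group gives the first clean step at this position, a 12-fold lower number from compound 3 to compound 4 (1.09 log units; beyond the scatter), which is large. Among the compounds shown here, the group on this carbon can therefore shift the read-out strongly, while the only other single-place step, a 1.4-fold lower number from compound 1 to compound 2 (0.14 log units; within the scatter), sits at a different place and stays within the scatter. The entering group differs from the leaving one by a triple bond outside aromatic rings and a hydrogen-bond acceptor, but nothing at hand bears on why the number falls.

The single step changes two things at once, the loss of the methyl and the arrival of the nitrile, so the compounds shown cannot say whether either alone accounts for the drop or whether both are needed. Also open, from the compounds shown here alone, is how the read-out at this position would respond to an aryl group carrying an amine or a carboxylic acid, or to a plain phenyl group.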